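This account rests on a few compounds, and the source may have more. Where it says the series, first, only, none or still open, it means among the compounds named here.

Working notes on the series. Compound 3 `COc1cc(/C=C/C(=O)Nc2cc3c(Nc4ccc(F)c(Cl)c4)ncnc3cc2O[C@H]2CCOC2)cc(OC)c1OC` gives 20500 nM in a functional assay on PC-3 cells (Homo sapiens) for cytotoxicity, read by MTT assay, with a stated time of 72 h; a higher number here means a weaker inhibitor, a lower number a stronger inhibitor; it has the lowest of the three numbers, but compound 1 `O=C(/C=C/c1ccc([N+](=O)[O-])cc1)Nc1cc2c(Nc3ccc(F)c(Cl)c3)ncnc2cc1O[C@H]1CCOC1` with 22800 nM and compound 2 `COc1cc(/C=C/C(=O)Nc2cc3c(Nc4ccc(F)c(Cl)c4)ncnc3cc2O[C@H]2CCOC2)cc(OC)c1O` with 26500 nM both lie within the scatter of it, so no order among the three can be claimed. Compound 4 `COc1ccc(/C=C/C(=O)Nc2cc3c(Nc4ccc(F)c(Cl)c4)ncnc3cc2O[C@H]2CCOC2)c(OC)c1` is not yet measured in this assay. Its change from compound 3 is 2,4-dimethoxyphenyl in place of 3,4,5-trimethoxyphenyl on a double-bonded chain carbon bound to a double-bonded chain carbon. The comparable swaps of the aryl group on the chain, a 1.1-fold lower number from compound 1 to compound 3 (0.05 log units; within the scatter) and a 1.3-fold lower number from compound 2 to compound 3 (0.11 log units; within the scatter), both stayed within the scatter, so no step beyond the scatter is expected in either direction. Compound 4 is therefore expected at about 21000 nM in this assay, range 10000 nM to 45000 nM, a step of a 1.0-fold higher number from compound 3 to compound 4 (0.01 log units; within the scatter).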

Compound 4, half-maximal inhibitory concentration: 2760 nM
The estimate for compound 4 lay 7.6-fold (0.88 log units) above the measured number; the whole stated range lies above it.
By their numbers in this assay, from the lowest: compound 4; then compounds 3, 1 and 2 (each within the scatter of the next).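

In this assay the aryl group on the chain can now be seen to matter: the swaps to 2,4-dimethoxyphenyl give a 7.4-fold lower number from compound 3 to compound 4 (0.87 log units; beyond the scatter) and a 9.6-fold lower number from compound 2 to compound 4 (0.98 log units; beyond the scatter) and an 8.3-fold lower number from compound 1 to compound 4 (0.92 log units; beyond the scatter), while the three earlier aryl groups stayed within the scatter of one another. Among these four compounds, only 2,4-dimethoxyphenyl moves the number beyond the scatter at this place. No measurement available here accounts for the step.

On these data alone, whether both methoxy groups are needed stays open, as does whether a dimethylamino group or a chlorine in place of either one would keep the lower number.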